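A Larger Ether Substituent in Place of Pyrimidin-5-yl

The compounds below may be only part of what the source reports. "The series", "measured", "known", "first", "only" and "open" are said of these compounds alone.

Compound 1 `O=C1C(=O)N(Cc2ccc(-c3cncnc3)cc2)c2ccc(OC(F)(F)F)cc21` is one of three compounds tested in a functional assay on CHO cells for positive allosteric modulation of muscarinic acetylcholine receptor M5 (Homo sapiens), read by FLIPR and calcium flux, with a stated time of 1 h (on this read-out lower numbers stand for smaller maximal responses and higher numbers for larger maximal responses), where compound 1 reaches 53%. Compound 2 `O=C1C(=O)N(Cc2ccc(-c3ccncc3)nc2)c2ccc(OC(F)(F)F)cc21` gives 50%, within the scatter of compound 1, while compound 3 `O=C1C(=O)N(Cc2ccc(Cl)nc2)c2ccc(OC(F)(F)F)cc21` gives 80%, so compound 1 stands second highest of the three. Among the measured compounds shown here, the only single-point step, a number 30 percentage points higher from compound 2 to compound 3 (beyond the scatter), is chloro in place of pyridin-4-yl, a change unlike the one considered here. Compound 4 `COc1cccc(Oc2ccc(CN3C(=O)C(=O)c4cc(OC(F)(F)F)ccc43)cc2)n1` differs from compound 1 by (6-methoxypyridin-2-yl)oxy in place of pyrimidin-5-yl on an aromatic carbon. For the measured compounds named here, no measured step shares this change, so for compound 4 only a small change in this assay is expected, a number 2 percentage points higher from compound 1 to compound 4 (within the scatter). Compound 4 is therefore estimated to give 55%, within a range from 35% to 80%.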

Compound 4, largest response reached (Emax), in percent of the reference or control that the assay uses: 51%
For compound 4 the middle estimate is 4 percentage points above the measured one; low and high end bracket the measured number.
By their numbers in this assay, from the lowest: compounds 2, 4 and 1 (each within the scatter of the next); then compound 3.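

In this assay the swap gives a number 2 percentage points lower from compound 1 to compound 4 (within the scatter) and thus no step beyond the scatter. On this six-membered aromatic ring of carbon only, para to a large group, the position therefore accepts (6-methoxypyridin-2-yl)oxy in place of pyrimidin-5-yl, although the entering group has more heavy atoms and one fewer ring hetero atom. Nothing available explains why the number holds. The compounds shown leave open whether an amine or a carboxylic acid at this position would give a similar number, and whether the entering group needs its methoxy.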